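This account rests on a few compounds, and the source may have more. Where it says the series, first, only, none or still open, it means among the compounds named here.

Measured compounds in an assay for inhibition of Thromboxane-A synthase (Homo sapiens), using microsomes; a higher number here means a weaker inhibitor, a lower number a stronger inhibitor:
compound 1, `CC(C)(C)c1ccc(OC(C)(C)C2OCC(C/C=C\CCC(=O)O)C(c3cccnc3)O2)cc1`, 280 nM
compound 2, `COc1ccccc1OC(C)(C)C1OCC(C/C=C\CCC(=O)O)C(c2cccnc2)O1`, 60 nM
compound 3, `CC(C)(Cc1ccccc1)C1OCC(C/C=C\CCC(=O)O)C(c2cccnc2)O1`, 12 nM

Compound 3 holds the lowest of the three numbers in this assay. Its nearest neighbour is compound 2, which reads 60 nM, and the furthest is compound 1 at 280 nM; both of these gaps lie beyond the scatter. The three steps measured so far are a 4.7-fold lower number from compound 1 to compound 2 (0.67 log units; beyond the scatter), a 23-fold lower number from compound 1 to compound 3 (1.37 log units; beyond the scatter) and a 5.0-fold lower number from compound 2 to compound 3 (0.70 log units; beyond the scatter); each of them exchanges the whole group carried on the saturated chain carbon, or the aryl on its oxygen, for a different one.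

Compound 4, `CC(C)(Cc1ccc(F)cc1)C1OCC(C/C=C\CCC(=O)O)C(c2cccnc2)O1`, keeps the benzyl of compound 3 and differs only by fluoro in place of hydrogen on an aromatic carbon, on an aromatic carbon of a six-membered aromatic ring of carbon only, para to a large group. Among the compounds with values here, none of the measured steps touches a substituent on this ring, so no measured step bears directly on the change; the measured steps all concern a larger exchange than a single fluoro entering for hydrogen. Within the data shown here, with no comparable precedent, the expected outcome is a number close to that of compound 3, with no step beyond the scatter: no change at the digits printed from compound 3 to compound 4 (within the scatter) is the estimate. Compound 4 is therefore estimated at 12 nM in this assay, with a range from 5 nM to 30 nM.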

Compound 4, half-maximal inhibitory concentration: 45 nM
Beside the measured number, compound 4's estimate is 3.8-fold (0.57 log units) below it; the whole stated range lies below it.
By their numbers in this assay, from the lowest: compound 3; then compounds 4 and 2 (each within the scatter of the next); then compound 1.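

In this assay, the ring of the benzyl group proves sensitive to a very small exchange: fluoro in place of hydrogen on an aromatic carbon, para to a large group, gives a 3.8-fold higher number from compound 3 to compound 4 (0.57 log units; beyond the scatter), so this position does not tolerate the change silently. The 4-fluorobenzyl group also gives up the clear separation that benzyl held over 2-methoxyphenoxy, which stood at a 5.0-fold lower number from compound 2 to compound 3 (0.70 log units; beyond the scatter), for a 1.3-fold lower number from compound 2 to compound 4 (0.12 log units; within the scatter), so these two compounds cannot be ordered, although the separation from 4-(tert-butyl)phenoxy remains at a 6.2-fold lower number from compound 1 to compound 4 (0.79 log units; beyond the scatter). Nothing available explains why a single fluoro shifts the number in this direction.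

The compounds shown leave open whether the shift is particular to fluoro or would follow any group at this position, for example chloro, methyl, methoxy or hydroxyl. They also leave open whether fluoro on another aromatic carbon of the same ring, or a second fluoro on that ring, would give a similar step in this assay.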